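The compounds below may be only part of what the source reports. "The series", "measured", "known", "first", "only" and "open" are said of these compounds alone.

Measured compounds:
- compound 1 `O=C(O)CCc1nc2ccccc2nc1OCc1ccccc1`: "not active" (no number reported)
- compound 2 `Cn1c(=O)c(CCC(=O)O)nc2ccccc21`: 70000 nM
- compound 3 `O=C(O)CCn1nc(-c2cccnc2)ccc1=O`: 350000 nM

In an assay for displacement of a labelled ligand from protein deacetylase HDAC6 (Homo sapiens), read by fluorescence polarization, with a stated time of 10 min (a lower number here means a stronger inhibitor, a higher number a weaker inhibitor), compound 1 gave "not active" (no number reported) and so carries no number at all, which leaves it without a place on the scale set by compound 2 and compound 3. Both of those give weak numbers, so the shared theme here is weak binding throughout. Compound 4 `O=C(O)CCc1nc2ccccc2nc1OCc1ccccn1` differs from compound 1 in a single place: pyridin-2-yl in place of phenyl on a saturated chain carbon bound to an oxygen on an aromatic ring. Among the measured compounds shown here, with no measured pair of this kind, the expected size of the step in this assay is small, most likely within the usual scatter, and with a fair chance that compound 4 again returns no number. Where a number does appear, compound 4 is estimated at 200000 nM, with a range from 50000 nM to 800000 nM.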

Compound 4, half-maximal inhibitory concentration: 270000 nM
Beside the measured number, compound 4's estimate is 1.4-fold (0.13 log units) below it, and the stated range covers the measured number.
By their numbers in this assay, from the lowest: compound 2; then compounds 4 and 3 (each within the scatter of the next).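

In this assay, among the compounds shown here, compound 1 gave "not active" (no number reported) and so no step from it to compound 4 can be read. No evidence at hand bears on this result. From the compounds shown here alone, what pyridin-2-yl in place of phenyl does to binding stays open.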